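Compound 3: bromo in place of methyl

A few compounds are considered here, and "the series" means these few. Any claim that something is new, unique, unknown or untested is made for them only; others in the source may bear on it.

In a functional assay on MCF7 cells (Homo sapiens) for antiproliferative activity, read by MTT assay, with a stated time of 72 h (on this read-out lower numbers stand for stronger inhibition and higher numbers for weaker inhibition), compound 1 (`COc1ccc(NC(=S)Nc2nc(C(=O)NCCCc3ccccc3)cs2)cc1`) gives 63800 nM, and compound 2 (`CCOC(=O)c1csc2nc(CN3CCN(C)CC3)c(-c3ccc(C)cc3)n12`) gives 58300 nM. Compound 3 (`CCOC(=O)c1csc2nc(CN3CCN(Cc4ccccc4)CC3)c(-c3ccc(C)cc3)n12`) gives 29100 nM, a number within the scatter of compound 2 and beyond the scatter of the higher number of compound 1.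

Compound 4 (`CCOC(=O)c1csc2nc(CN3CCN(Cc4ccccc4)CC3)c(-c3ccc(Br)cc3)n12`) differs from compound 3 in one place: bromo in place of methyl on an aromatic carbon. In words, this is bromo in place of methyl on an aromatic carbon, para to a large group, or 4-methylphenyl to 4-bromophenyl.

Going by the values given here, the only measured step between compounds that differ in one place is a 2.0-fold lower number from compound 2 to compound 3 (0.30 log units; within the scatter). It puts phenyl in place of hydrogen on a saturated chain carbon bound to an amine nitrogen in a ring, which is a different site from the one changed here. No measured pair changes the group on this aromatic carbon, so the size of this swap is not shown directly.

Resting on compound 3 at 29100 nM and on a 2.0-fold lower number from compound 2 to compound 3 (0.30 log units; within the scatter) as the only size reference, no shift beyond the scatter is expected in this assay. The expected step is a 1.1-fold lower number from compound 3 to compound 4 (0.05 log units; within the scatter). For compound 4 the estimated value is 26000 nM, with an expected range from 11000 nM to 60000 nM.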

Compound 4, half-maximal inhibitory concentration: 51400 nM
For compound 4 the middle estimate is 2.0-fold (0.30 log units) below the measured one, and the stated range covers the measured number.
By their numbers in this assay, from the lowest: compounds 3, 4, 2 and 1 (each within the scatter of the next, the first and the last beyond it).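

In this assay, going by these compounds alone, the swap from 4-methylphenyl to 4-bromophenyl gives a 1.8-fold higher number from compound 3 to compound 4 (0.25 log units; within the scatter), the first measured pair at this aromatic carbon, and on this pair methyl and bromo cannot be told apart. Like a 2.0-fold lower number from compound 2 to compound 3 (0.30 log units; within the scatter), this step stays within the scatter, so neither of the two single changes read so far, one on the aromatic carbon and one on the saturated chain carbon bound to the ring amine nitrogen, separates its pair of compounds. No supporting measurement is available to explain the values of this pair.

Going by these compounds, whether any group on this aromatic carbon can move the number beyond the scatter stays open, and a methoxy, a nitrile, a hydroxyl or a carboxylic acid there would put that to the test. The ethyl ester is shared by compound 2, compound 3 and compound 4, so the effect of a carboxylic acid or an amide in its place also remains an open question.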